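Swapping the Five-Membered Ring for a Six-Membered One

The source may hold more compounds than are shown below. What is called first, only, known or untested is meant among the compounds shown, and "the series" means these compounds.

Compound 1 `CCCOP(=O)(O)OCCSC(=S)N1CCCC1`: 67000 nM
Compound 2 `CCCCCCCCCCOP(=O)(O)OCCSC(=S)N1CCCC1`: 67000 nM
Compound 3 `CCCCCCCCOP(=O)(O)OCCSC(=S)N1CCCC1`: 69000 nM

In a functional assay on MDA-MB-231 cells (Homo sapiens) for inhibition, read by MTT assay, with stated times of 18 h and 4 h (on this read-out lower numbers stand for stronger inhibition and higher numbers for weaker inhibition), compound 2 stands level with compound 1 at the digits shown, the two together the lowest of the three numbers, while the number for compound 3 differs from them only within the scatter. Compound 4 `CCCCCCCCCCOP(=O)(O)OCCSC(=S)N1CCCCC1` differs from compound 2 by piperidin-1-yl in place of pyrrolidin-1-yl on a thiocarbonyl carbon. Among the measured compounds shown here, none of the measured steps touches this ring: no change at the digits printed from compound 1 to compound 2 (within the scatter), a 1.0-fold higher number from compound 1 to compound 3 (0.01 log units; within the scatter) and a 1.0-fold higher number from compound 2 to compound 3 (0.01 log units; within the scatter) all concern the length of the chain and all stay within the scatter, so the data give no guide for the ring change. With nothing pointing either way, no step beyond the scatter is expected, which means no change at the digits printed from compound 2 to compound 4 (within the scatter). Compound 4 is therefore estimated at 67000 nM, within a range of 30000 nM to 150000 nM.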

Compound 4, half-maximal inhibitory concentration: 24600 nM
For compound 4 the middle estimate is 2.7-fold (0.44 log units) above the measured one; measured number below the stated range.
By their numbers in this assay, from the lowest: compound 4; then compounds 1, 2 and 3 (each within the scatter of the next).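

In this assay, the group on the thiocarbonyl carbon turns out to matter: piperidin-1-yl in place of pyrrolidin-1-yl gives a 2.7-fold lower number from compound 2 to compound 4 (0.44 log units; beyond the scatter) as a modest step. None of the chain changes among compounds 1, 2 and 3 moved the number beyond the scatter, so this is the first change shown to do so. Nothing at hand indicates why the larger ring gives the lower number.

From the compounds shown here alone, whether the same swap holds on the shorter chains of compounds 1 and 3 remains open. So does the outcome with a morpholin-4-yl or azepan-1-yl group on this carbon.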